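Adding a Phenyl Group to a Poorly Stable Core

The compounds below may be only part of what the source reports. "The series", "measured", "known", "first", "only" and "open" are said of these compounds alone.

Compound 1 `Cc1sc2ncnc(Oc3ccccc3F)c2c1C` gives < 5% in an ADME assay on microsomes from liver (Mus musculus) for metabolic stability, read by LC-MS, using NADPH, with a stated time of 60 min; on this read-out lower numbers stand for a less stable compound and higher numbers for a more stable compound.
Compound 2 `CC(C)(C)c1cc2c(Oc3ccccc3F)ncnc2s1` gives < 5% in this assay.

Both of these values are limits of the measurement, not numbers. On these data alone, compound 2 therefore stands at the limit of < 5% in this assay, at which 2 of the 2 values shown sit, and how far its stability lies beyond that limit is unknown. Compound 3 `CC(C)(C)c1sc2ncnc(Oc3ccccc3F)c2c1-c1ccccc1` differs from compound 2 by phenyl in place of hydrogen on an aromatic carbon. For the measured compounds named here, no measured pair here shows how such a change shifts this read-out, so no move beyond the usual scatter is expected in this assay. The expected step is a number no lower from compound 2 to compound 3 (the limit leaves the size open). Compound 3 is expected to give about 5%, within 0% to 15%.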

Compound 3, percent of the compound remaining: < 5%
Compound 3: no number, only a limit; the forecaster's own chance of this, stated with the estimate: 60%; the middle value lies on the limit itself.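

No step can be read from compound 2 to compound 3, because both give a limit of the measurement, not a number: the limit of < 5% in this assay, at which 3 of the 3 values shown sit.

On these data alone, what phenyl in place of hydrogen changes in this assay stays open, as does how far either compound lies beyond that limit.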